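From Nitro to Methyl at the Assay Limit

This account rests on a few compounds, and the source may have more. Where it says the series, first, only, none or still open, it means among the compounds named here.

In an ADME assay on HeLa cells (Homo sapiens) for cytotoxicity, read by MTT assay (on this read-out lower numbers stand for higher toxicity in this test and higher numbers for lower toxicity in this test), compound 2 (`Cc1nc(-c2cccnc2)sc1-c1nnc(-c2ccc([N+](=O)[O-])cc2)o1`) gives only a limit, > 100 ug/mL. Compound 1 (`Cc1nc(-c2cccnc2)sc1-c1nnc(-c2ccccc2Cl)o1`) also gives only a limit, > 100 ug/mL. Compound 3 (`COc1ccccc1-c1nnc(-c2sc(-c3cccnc3)nc2C)o1`) likewise gives only a limit, > 100 ug/mL. The measured evidence therefore comes down to the limit of > 100 ug/mL in this assay, at which 3 of the 3 values shown sit.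

Compound 4 (`Cc1ccc(-c2nnc(-c3sc(-c4cccnc4)nc3C)o2)cc1`) has methyl in place of nitro on an aromatic carbon, para to a large group: methyl in place of nitro on an aromatic carbon. Going by the values given here, the one measured step that bears on this change is a step that the two limits leave unreadable from compound 1 to compound 3, with methoxy in place of chloro on an aromatic carbon. It concerns a different substituent and gives no size to carry over. With no readable step to draw on, no change beyond the scatter is expected in this assay, and compound 4 is expected to reach the same limit. The expected step is a step that the limit leaves unreadable from compound 2 to compound 4. For compound 4 the estimated value is 150 ug/mL, with an expected range of 80 ug/mL to 300 ug/mL.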

Compound 4, half-maximal cytotoxic concentration: > 100 ug/mL
Compound 4 was reported as a limit; the forecaster's own chance of this, stated with the estimate: 85%; the middle value is on the limit's open side.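

Compound 4 gives > 100 ug/mL in this assay as a limit, not a number. Going by these compounds alone, no step among compound 1, compound 2, compound 3 and compound 4 can be read, since all stand at one limit: the limit of > 100 ug/mL in this assay, at which 4 of the 4 values shown sit. The compounds shown leave open whether any of these substituents changes the half-maximal cytotoxic concentration.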